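The source may report more compounds than this note shows. Statements on the series, on what has been measured and on what is new or still open speak of the compounds shown alone.

Measured so far in a functional assay on the whole organism (strain C57Bl/6) for inhibition, with Mus musculus as the target, with a stated time of 180 min, at 48 degrees C; a higher number here means that more compound is needed for the effect, a lower number that less compound is needed:
compound 1 `COc1ccc(Cn2c(=O)nc(NCCNC(=N)N)n(Cc3ccc(Br)cc3)c2=O)cc1`: 0.0043 nM
compound 2 `COc1ccc(Cn2c(NCCNC(=N)N)nc(=O)n(Cc3ccc(Br)cc3)c2=O)cc1`: 0.00036 nM
compound 3 `CCc1ccc(Cn2c(=O)nc(NCCNC(=N)N)n(Cc3ccc(OC)cc3)c2=O)cc1`: 0.0058 nM

Compound 1 stands second highest of the three numbers; compound 3 lies within the scatter of it, while compound 2 sits well below it, beyond the scatter. Compound 4 `COc1ccc(Cn2c(NCCNC(=N)N)nc(=O)n(Cc3ccc(OC)cc3)c2=O)cc1` differs from compound 1 in one place: methoxy in place of bromo on an aromatic carbon. For the measured compounds named here, no measured step swaps bromo for methoxy. Going by the values given here, the only step touching the bromo position, a 16-fold higher number from compound 2 to compound 3 (1.21 log units; beyond the scatter), runs on the isomeric core of compound 2 and brings in ethyl, not methoxy, so it bears only loosely here. Taking it as a hint that replacing bromo raised the number, a modest upward step from compound 1 is expected, a 2.8-fold higher number from compound 1 to compound 4 (0.45 log units; beyond the scatter). Compound 4 is therefore estimated at 0.012 nM, range 0.002 nM to 0.06 nM.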

Compound 4, half-maximal effective concentration: 0.000053 nM
Compound 4: the middle estimate sits 230-fold (2.35 log units) above what was measured; measured number below the stated range.
By their numbers in this assay, from the lowest: compound 4; then compound 2; then compounds 1 and 3 (each within the scatter of the next).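

In this assay methoxy in place of bromo lowers the number in both places where bromo stood, with an 81-fold lower number from compound 1 to compound 4 (1.91 log units; beyond the scatter) and with a 6.8-fold lower number from compound 2 to compound 4 (0.83 log units; beyond the scatter) on the other benzyl group. Methoxy in place of ethyl goes the same way, with a 110-fold lower number from compound 3 to compound 4 (2.04 log units; beyond the scatter) in this series, so of the three groups compared at this aromatic carbon, methoxy gives the lowest number. Nothing at hand accounts for these steps.

Going by these compounds, whether this holds only for methoxy remains open. Hydroxy, fluoro or the longer ethoxy on the same aromatic carbon could fall on either side of it.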